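A few compounds are considered here, and "the series" means these few. Any claim that something is new, unique, unknown or untested is made for them only; others in the source may bear on it.

Measured so far:
compound 1, `CCc1nc2cc3c(cc2o1)C1CNCC3C1`, which in an assay for binding affinity to Neuronal acetylcholine receptor; alpha4/beta2 (Rattus norvegicus) (a higher number here means a weaker inhibitor, a lower number a stronger inhibitor), gives 12 nM;
compound 2, `Cc1cnc2cc3c(cc2c1)C1CNCC3C1`, which in this assay gives 0.65 nM;
compound 3, `CC(C)c1nc2cc3c(cc2o1)C1CNCC3C1`, which in this assay gives 7.6 nM.

Compound 3 differs from compound 1 by methyl in place of hydrogen on a saturated chain carbon bound to an aromatic carbon and a saturated chain carbon, and this gave a 1.6-fold lower number from compound 1 to compound 3 (0.20 log units; within the scatter). Compound 2 is built on another core; the difference between the two cores is not broken down here. Of the three, compound 2 gives the lowest number.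

Compound 4, `CCc1cnc2cc3c(cc2c1)C1CNCC3C1`, has not yet been measured. It differs from compound 2 by methyl in place of hydrogen on a saturated chain carbon bound to an aromatic carbon. This is the same kind of change as that from compound 1 to compound 3, though the place is not identical: in compound 1 the saturated chain carbon is bound to an aromatic carbon and a saturated chain carbon, whereas in compound 2 it is bound to an aromatic carbon.

Because a 1.6-fold lower number from compound 1 to compound 3 (0.20 log units; within the scatter) stayed within the scatter, the step from compound 2 to compound 4 is expected to be small, a 1.2-fold higher number from compound 2 to compound 4 (0.09 log units; within the scatter). For compound 4 the value expected in this assay is 0.8 nM, estimated to lie between 0.3 nM and 2.5 nM.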

Compound 4, inhibition constant: 1.2 nM
Compound 4: the middle estimate sits 1.5-fold (0.18 log units) below what was measured, within the range that was stated.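

The methyl in place of hydrogen on a saturated chain carbon bound to an aromatic carbon, which turns methyl to ethyl on the core of compound 2, gave a 1.8-fold higher number from compound 2 to compound 4 (0.27 log units; within the scatter) and so stayed within the scatter. Each of the two steps is small taken alone, yet the change does not carry over as one fixed amount from one core to the other in this assay: the same change on two cores in this assay, a 1.6-fold lower number (0.20 log units; within the scatter) from compound 1 to compound 3 and a 1.8-fold higher number (0.27 log units; within the scatter) from compound 2 to compound 4, 2.9-fold (0.46 log units) apart, beyond the scatter of two such steps. This rests on a single pair on each core, and it shows neither why the two steps differ nor how the change would act on any further core.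

The compounds shown leave open how a longer chain, an amine or a carboxylic acid in this place would behave on either core.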